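Moving the Bromine Around the Ring: Cytotoxicity in HEL Cells

The compounds below may be only part of what the source reports. "The series", "measured", "known", "first", "only" and "open" are said of these compounds alone.

Measured compounds:
Compound 1, `C/C(=N\NC(=O)COc1cccc2ccccc12)c1ccccc1`: 20 ug/mL
Compound 2, `C/C(=N\NC(=O)COc1cccc2ccccc12)c1ccc(Br)cc1`: 20 ug/mL

This account concerns two hydrazones built on a shared core and a further compound that has not yet been tested. In an ADME assay on HEL cells (Homo sapiens) for cytotoxicity (on this read-out lower numbers stand for higher toxicity in this test and higher numbers for lower toxicity in this test), compound 1 gives 20 ug/mL. Compound 2 carries a bromo in place of hydrogen on an aromatic carbon, and in this assay compound 2 gives 20 ug/mL, so the step of no change at the digits printed from compound 1 to compound 2 (within the scatter) shows that adding the bromine left the cytotoxicity where it was. Compound 2 therefore stands level with compound 1 on the numbers shown.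

Compound 3, `C/C(=N\NC(=O)COc1cccc2ccccc12)c1ccccc1Br`, is the next member. Its difference from compound 2 is 2-bromophenyl in place of 4-bromophenyl on a carbon with a double bond to nitrogen: the two have the same atoms, joined differently. Going by the values given here, the only step measured so far, no change at the digits printed from compound 1 to compound 2 (within the scatter), concerns the bromine itself, not where it sits, and it was flat. With nothing pointing either way, compound 3 is expected to sit close to compound 2, so the step of no change at the digits printed from compound 2 to compound 3 (within the scatter) is estimated to lie within the scatter. Compound 3 is expected to give 20 ug/mL in this assay, with a range from 10 ug/mL to 40 ug/mL.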

Compound 3, minimum cytotoxic concentration in the HEL assay: 20 ug/mL
Estimate against measurement, compound 3: no gap at the digits printed; measured number inside the range.
By their numbers in the HEL assay, from the lowest: compounds 1, 2 and 3 (each within the scatter of the next).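

In the HEL assay there is no change at the digits printed from compound 2 to compound 3 (within the scatter), so moving the bromine from 4-bromophenyl to 2-bromophenyl leaves this read-out as flat as adding the bromine did, and for the 2-bromophenyl compound itself there is no change at the digits printed from compound 1 to compound 3 (within the scatter). In a physicochemical assay for lipophilicity, measured as octanol-water partition (a higher number here means a more lipophilic compound, a lower number a more polar compound), compound 2 gives 3.61 and compound 3 gives 4.44, so the same exchange of two groups with the same atoms does register on this second measure, as a number 0.83 log units higher from compound 2 to compound 3 (beyond the scatter). Compound 3 is therefore the more lipophilic of the pair, yet it stands level with compound 2 in the HEL assay, so in these two compounds a shift in lipophilicity of this size did not carry over into that read-out: the measured partition coefficient of compound 2, 3.61, and of compound 3, 4.44, a number 0.83 log units higher (beyond the scatter)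

The three compounds leave open whether the level read-out in the HEL assay is particular to bromine or would hold with an amine or a carboxylic acid on the phenyl ring in its place. They also leave open what a longer chain on the carbon with a double bond to nitrogen would do to either measure.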